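This account rests on a few compounds, and the source may have more. Where it says the series, first, only, none or still open, it means among the compounds named here.

In a functional assay on MOLT-4 cells (Homo sapiens) for inhibition, read by MTT assay, with a stated time of 48 h (a lower number here means a stronger inhibitor, a higher number a weaker inhibitor), compound 1 `O=C(/C=C/c1cn(-c2ccc(Cl)cc2)c2ccccc12)CC(=O)C(=O)O` gives 27000 nM and compound 2 `O=C(/C=C/c1cn(Cc2ccc(Cl)cc2)c2ccccc12)CC(=O)C(=O)O` gives 19000 nM. These two lie within the scatter of each other, as a 1.4-fold lower number from compound 1 to compound 2 (0.15 log units; within the scatter) shows. Compound 3 `N#Cc1ccc(Cn2cc(/C=C/C(=O)CC(=O)C(=O)O)c3ccccc32)cc1` has no number, only a limit of the assay, > 40000 nM.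

Compound 4 `CN(C)C(=O)Cn1cc(/C=C/C(=O)CC(=O)C(=O)O)c2ccccc21` carries dimethylcarbamoyl in place of 4-cyanophenyl on a saturated chain carbon bound to an aromatic nitrogen. The measured steps bear on this only loosely. One is an at least 2.1-fold higher number from compound 2 to compound 3 (0.32 log units; beyond the scatter), for cyano in place of chloro on an aromatic carbon, and the other is an at least 1.4-fold higher number from compound 1 to compound 3 (0.17 log units; that floor lies within the scatter). Neither removes the aromatic ring, so no step beyond the scatter is expected in this assay. The expected step is an at least 1.1-fold lower number from compound 3 to compound 4 (0.05 log units; that floor lies within the scatter). For compound 4 the estimate is 35000 nM, with an expected range of 15000 nM to 70000 nM.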

Compound 4, half-maximal inhibitory concentration: > 40000 nM
Compound 4 gave a limit, no number; the forecaster's own chance of this, stated with the estimate: 55%; at least 1.1-fold (0.05 log units) between middle value and limit.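

With dimethylcarbamoyl, which has no ring, in place of 4-cyanophenyl on this saturated chain carbon, compound 4 in this assay also ends at a limit of the assay, > 40000 nM, so losing that ring brings no readable number. The step from compound 3 to compound 4 cannot be read, because both rest on one limit: the limit of > 40000 nM in this assay, at which 2 of the 4 values shown sit. The remaining comparisons give an at least 2.1-fold higher number from compound 2 to compound 4 (0.32 log units; beyond the scatter) and an at least 1.4-fold higher number from compound 1 to compound 4 (0.17 log units; that floor lies within the scatter), and only the first clears the scatter.

As far as these compounds go, whether an amine, a carboxylic acid or a longer chain at this place would give a readable number stays open.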